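Nitro Addition on a Styryl Sulfonamide Anilide

The source may hold more compounds than are shown below. What is called first, only, known or untested is meant among the compounds shown, and "the series" means these compounds.

Measured compounds:
compound 1 `COc1cc(OC)c(/C=C/S(=O)(=O)Nc2cc([N+](=O)[O-])c(OC)c([N+](=O)[O-])c2)c(OC)c1`: 10000 nM
compound 2 `COc1ccc(NS(=O)(=O)/C=C/c2cc(OC)c(OC)c(OC)c2)cc1`: 35000 nM
compound 3 `COc1cc(OC)c(/C=C/S(=O)(=O)Nc2ccc(OC)c([N+](=O)[O-])c2)c(OC)c1`: 1000 nM

In a functional assay on K562 cells (Homo sapiens) for cytotoxicity, read by trypan blue exclusion, with a stated time of 96 h (on this read-out higher numbers stand for weaker inhibition and lower numbers for stronger inhibition), compound 3 gives the lowest number and compound 2 the highest. Going from compound 3 to compound 1 the change is nitro in place of hydrogen on an aromatic carbon, and it gave a 10-fold higher number from compound 3 to compound 1 (1.00 log units; beyond the scatter). Compound 4 `COc1ccc(NS(=O)(=O)/C=C/c2cc(OC)c(OC)c(OC)c2)cc1[N+](=O)[O-]` is not yet measured; it arises from compound 2 by nitro in place of hydrogen on an aromatic carbon, the same kind of change, though here the place is not also meta to a nitro group. The difference between the cores of compound 2 and compound 3 is not broken down here. Because the first such step, a 10-fold higher number from compound 3 to compound 1 (1.00 log units; beyond the scatter), weakened inhibition, compound 4 is expected to stay near compound 2, with a step of about a 2.3-fold lower number from compound 2 to compound 4 (0.37 log units; beyond the scatter). The estimate for compound 4 is 15000 nM, between 3000 nM and 60000 nM.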

Compound 4, half-maximal inhibitory concentration: 75000 nM
For compound 4 the middle estimate is 5.0-fold (0.70 log units) below the measured one, outside the stated range (above it).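

The new step, a 2.1-fold higher number from compound 2 to compound 4 (0.33 log units; beyond the scatter), shows that nitro in place of hydrogen on an aromatic carbon again weakened inhibition in this assay. The direction of the change carried over from one core to the other, but its size did not: the same change on two cores in this assay, a 10-fold higher number (1.00 log units; beyond the scatter) from compound 3 to compound 1 and a 2.1-fold higher number (0.33 log units; beyond the scatter) from compound 2 to compound 4, 4.7-fold (0.67 log units) apart, beyond the scatter of two such steps

These two pairs do not show why the size differs, and they give no rule for any further core. On these data alone, it remains open whether an amine or a carboxylic acid on the same aromatic carbon would shift the number in the same direction on both cores. Also open, as far as these compounds go, is which part of the difference between the two cores matters for the size of the step.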